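From piperidinyl to pyridinyl on a shared core

This account rests on a few compounds, and the source may have more. Where it says the series, first, only, none or still open, it means among the compounds named here.

Going by the values given here, compound 3 `COc1ccccc1C(=O)NC(=O)Nc1ccc(N2CCCCC2)c(C(F)(F)F)c1` holds the lowest of the three numbers measured so far in a physicochemical assay for solubility, in simulated intestinal fluid; a lower number here means a less soluble compound, a higher number a more soluble compound: compound 3 gives 4.1 ug/mL. Its nearest neighbour is compound 2 `COc1ccccc1C(=O)NC(=O)Nc1ccc(-c2nccs2)c(C(F)(F)F)c1`, which in this assay gives 12 ug/mL, and the furthest is compound 1 `COc1ccccc1C(=O)NC(=O)Nc1ccc(-c2ccccc2)c(C(F)(F)F)c1`, which in this assay gives 23 ug/mL. Between those two the step is a 1.9-fold lower number from compound 1 to compound 2 (0.28 log units; within the scatter).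

Compound 4 `COc1ccccc1C(=O)NC(=O)Nc1ccc(-c2ccccn2)c(C(F)(F)F)c1` differs from compound 3 in one place: pyridin-2-yl in place of piperidin-1-yl on an aromatic carbon. The measured steps that bear on this change run in the opposite direction, from a six-membered ring to piperidin-1-yl: a 5.6-fold lower number from compound 1 to compound 3 (0.75 log units; beyond the scatter) and a 2.9-fold lower number from compound 2 to compound 3 (0.47 log units; beyond the scatter). Both were modest and beyond the scatter, and both lowered the number. Undoing that exchange, with pyridin-2-yl entering in place of piperidin-1-yl, is therefore expected to raise the number in this assay by a modest step beyond the scatter, roughly a 4.4-fold higher number from compound 3 to compound 4 (0.64 log units; beyond the scatter). Compound 4 is estimated at 18 ug/mL, with a range from 7 ug/mL to 45 ug/mL.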

Compound 4, solubility: 8.5 ug/mL
Compound 4: the middle estimate sits 2.1-fold (0.33 log units) above what was measured, within the range that was stated.
By their numbers in this assay, from the lowest: compound 3; then compounds 4, 2 and 1 (each within the scatter of the next, the first and the last beyond it).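

In this assay, pyridin-2-yl and piperidin-1-yl match in heavy atoms, hydrogen-bond donors and acceptors, yet the aromatic ring on this carbon, ortho to a trifluoromethyl group, gives a modest rise over the non-aromatic one (a 2.1-fold higher number from compound 3 to compound 4 (0.32 log units; beyond the scatter)). The rise does not carry compound 4 all the way to the phenyl compound (a 2.7-fold lower number from compound 1 to compound 4 (0.43 log units; beyond the scatter)), while the step from the thiazole stays within the scatter (a 1.4-fold lower number from compound 2 to compound 4 (0.15 log units; within the scatter)). The aromatic groups therefore do not form one level, but piperidin-1-yl stays apart from all three, with compound 3 the lowest of the four.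

Nothing shown here accounts for these differences. On these data alone, it also remains open whether pyridin-3-yl, a morpholine ring or a carboxylic acid at this place would go beyond the number of compound 1.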